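Propyl in place of trifluoromethyl on the aryloxy ring

The compounds below may be only part of what the source reports. "The series", "measured", "known", "first", "only" and "open" are said of these compounds alone.

Three compounds have been measured in an assay on HEK293 cells for agonist activity at transient receptor potential cation channel subfamily M member 8 (Homo sapiens), read by fluorescence and calcium flux, with a stated time of 15 min; on this read-out higher numbers stand for an effect only at larger amounts of compound and lower numbers for an effect already at smaller amounts:
compound 1 `CCN(Cc1cccs1)C(=O)COc1ccc(F)cc1` gives 422 nM
compound 2 `CCN(Cc1cccs1)C(=O)c1cc2cc(C)ccc2o1` gives 120 nM
compound 3 `CCN(Cc1cccs1)C(=O)COc1ccc(C(F)(F)F)cc1` gives 236 nM

Compound 3 stands second highest of the three numbers. Its nearest neighbour is compound 1, reached by the step of a 1.8-fold lower number from compound 1 to compound 3 (0.25 log units; within the scatter). Compound 2 lies furthest away, and its value and that of compound 3 sit within the scatter of each other.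

Compound 4 `CCCc1ccc(OCC(=O)N(CC)Cc2cccs2)cc1` has not yet been measured. It differs from compound 3 in one place: propyl in place of trifluoromethyl on an aromatic carbon. Within the data shown here, the only measured step that touches this same place is a 1.8-fold lower number from compound 1 to compound 3 (0.25 log units; within the scatter), and it stayed within the scatter. Among the measured compounds shown here, no measured pair swaps a fluorinated group for an alkyl chain, so the step to compound 4 rests on that single comparison. Compound 4 is therefore expected to show no change beyond the scatter, an estimated step of a 1.1-fold lower number from compound 3 to compound 4 (0.03 log units; within the scatter). The estimate for compound 4 is 220 nM, with a range from 80 nM to 600 nM.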

Compound 4, half-maximal effective concentration: 1810 nM
Beside the measured number, compound 4's estimate is 8.2-fold (0.92 log units) below it, outside the stated range (above it).
By their numbers in this assay, from the lowest: compounds 2, 3 and 1 (each within the scatter of the next, the first and the last beyond it); then compound 4.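

Fluoro and trifluoromethyl had read alike at this aromatic carbon, para to a large group, so compounds 1 and 3 gave no sign that the position was sensitive to change. Propyl shows that it is: in this assay the change reads a 7.7-fold higher number from compound 3 to compound 4 (0.88 log units; beyond the scatter) and, set against fluoro, a 4.3-fold higher number from compound 1 to compound 4 (0.63 log units; beyond the scatter) with both steps running the same way and beyond the scatter. So this position does discriminate between substituents, with propyl on the unfavourable side of both fluorinated groups, but nothing shown here accounts for the shift.

The compounds shown leave open how methyl, ethyl or a longer chain such as butyl would read at this position, and so whether the rise belongs to propyl alone or to alkyl chains in general. They also leave open whether an amine or a carboxylic acid here would read like the fluorinated groups or like propyl.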